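The source may report more compounds than this note shows. Statements on the series, on what has been measured and on what is new or still open speak of the compounds shown alone.

Measured so far in an assay on cell membranes for displacement of a labelled ligand from Neuronal acetylcholine receptor; alpha4/beta2 (Rattus norvegicus); a lower number here means a stronger inhibitor, a higher number a weaker inhibitor:
compound 1, `COC1=NOC2(CCC[N+](C)(C)C2)C1`: 94000 nM
compound 2, `BrC1=NOC2(CCCNC2)C1`: 58000 nM
compound 3, `c1ccc(C2=NOC3(C2)CN2CCC3C2)cc1`: 53000 nM

All three numbers sit in the weak range. Compound 1 carries the top number of the three, but its gaps to compound 2 and to compound 3 both lie within the usual scatter, so the three compounds cannot be told apart on these data.

The next compound, compound 4, `C[N+]1(C)CCCC2(CC(Br)=NO2)C1`, keeps the core of compound 1 and differs from it in one place: bromo in place of methoxy on a carbon with a double bond to nitrogen. Going by the values given here, no step between measured compounds shows what this change does on its own. Compound 2, which also carries bromo, gives 58000 nM, and that is the only hint available. On that basis compound 4 is expected to stay weak, with a step of a 1.6-fold lower number from compound 1 to compound 4 (0.19 log units; within the scatter) that is likely not beyond the scatter. The estimate for compound 4 is 60000 nM, within 20000 nM to 200000 nM.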

Compound 4, inhibition constant: 50000 nM
For compound 4 the middle estimate is 1.2-fold (0.08 log units) above the measured one; the range from low to high includes it.
By their numbers in this assay, from the lowest: compounds 4, 3, 2 and 1 (each within the scatter of the next).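

Going by these compounds alone, this is the first matched step at this position: in this assay, bromo in place of methoxy gives a 1.9-fold lower number from compound 1 to compound 4 (0.27 log units; within the scatter) and so does not separate the two compounds. On the core of compound 1, both groups leave the number in the weak range. Nothing measured here offers an explanation for this result.

Still open, on these data alone, is whether an amine or a hydroxyl group on this carbon would give a step beyond the scatter. Also open, as far as these compounds go, is whether the same exchange would read alike on the core of compound 2.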